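Notes on the chloro step from compound 2

A few compounds are considered here, and "the series" means these few. Any claim that something is new, unique, unknown or untested is made for them only; others in the source may bear on it.

Measured in a functional assay on HeLa cells (Homo sapiens) for cytotoxicity, read by sulforhodamine B assay, with a stated time of 48 h; a lower number here means a stronger inhibitor, a higher number a weaker inhibitor:
- compound 1 `O=C(c1cccnc1)c1ccccc1O`: 33000 nM
- compound 2 `C=CCOc1ccc(Cl)cc1C(=O)c1cccnc1`: 75000 nM

Of these two measured compounds, compound 2 at 75000 nM carries the higher number, and its gap to compound 1 lies beyond the scatter. It is therefore the weaker inhibitor of the pair in this assay.

Compound 3 `C=CCOc1ccccc1C(=O)c1cccnc1` is the next case. It differs from compound 2 at one place: hydrogen in place of chloro on an aromatic carbon, with hydrogen in place of chloro on an aromatic carbon, para to the allyloxy group, which stays. Among the compounds with values here, no measured pair in this set shows this change, so the expectation has little to rest on. The estimated 1.2-fold lower number from compound 2 to compound 3 (0.06 log units; within the scatter) lies within the scatter, so no clear move in either direction is expected. For compound 3 the estimated value is 65000 nM, with an expected range of 30000 nM to 140000 nM.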

Compound 3, half-maximal inhibitory concentration: > 100000 nM
Compound 3 gave a limit, no number; the forecaster's own chance of this, stated with the estimate: 10%; middle value at least 1.5-fold (0.18 log units) from the limit.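

In this assay compound 3 gives a limit and not a number: the limit of > 100000 nM in this assay, at which 1 of the 3 values shown sits. Hydrogen in place of chloro, para to the allyloxy group, gives an at least 1.3-fold higher number from compound 2 to compound 3 (0.12 log units; that floor lies within the scatter), so this first reading at the position has only a floor, and that floor cannot show whether the chloro matters. Within the data shown here, the first clear single-place change is allyl in place of hydrogen on an oxygen on an aromatic ring, which gives an at least 3.0-fold higher number from compound 1 to compound 3 (0.48 log units; beyond the scatter) and so places the allyl ether on the weaker side of the free hydroxyl in this pair.

From the compounds shown here alone, with only chloro and hydrogen at this position, the reading of an amine or a methoxy group there remains open. On the oxygen, a methyl group or a longer chain could show whether the step depends on the allyl group itself.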